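From a ring to an open chain

A few compounds are considered here, and "the series" means these few. Any claim that something is new, unique, unknown or untested is made for them only; others in the source may bear on it.

Measured so far in a physicochemical assay for solubility, read by spectrophotometry, using the shake flask method, with a stated time of 2 days, at pH 6.5; a higher number here means a more soluble compound, a lower number a less soluble compound:
- compound 1 (`Oc1ccc(-n2cc(-c3ccc4cc(OCC5CCCCO5)ccc4n3)nn2)cc1`) gives (3.4 ug/mL)
- compound 2 (`O=C(O)CCCOc1ccc2nc(-c3cn(-c4ccc(O)c(F)c4)nn3)ccc2c1`) gives (19.2 ug/mL)

Compound 1 holds the lower of these two numbers, and compound 2 stands above it by more than the usual scatter. Compound 3 (`COCCOCCOc1ccc2nc(-c3cn(-c4ccc(O)cc4)nn3)ccc2c1`) has not yet been measured. It departs from compound 1 in one place ((2-methoxyethoxy)methyl in place of oxan-2-yl on a saturated chain carbon bound to an oxygen on an aromatic ring): (2-methoxyethoxy)methyl in place of oxan-2-yl on a saturated chain carbon bound to an oxygen on an aromatic ring. Going by the values given here, no measured pair shows a single change, so the expectation rests on this change and on the starting point of compound 1 (3.4 ug/mL). A moderate rise in this assay is expected, probably just beyond the scatter. The expected step is an estimate (a 2.4-fold higher number from compound 1 to compound 3 (0.37 log units; beyond the scatter)). The estimated value for compound 3 is 8 ug/mL (expected range 3 ug/mL to 25 ug/mL).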

Compound 3, solubility: 2.4 ug/mL
Beside the measured number, compound 3's estimate is 3.3-fold (0.52 log units) above it, outside the stated range (below it).
By their numbers in this assay, from the lowest: compounds 3 and 1 (each within the scatter of the next); then compound 2.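

In this assay, replacing oxan-2-yl with (2-methoxyethoxy)methyl on a saturated chain carbon bound to an oxygen on an aromatic ring gives a 1.4-fold lower number from compound 1 to compound 3 (0.15 log units; within the scatter) and so produces no readable difference. At this position, then, a ring and an open chain of 6 heavy atoms each cannot be told apart in this read-out, even though the chain carries 2 hydrogen-bond acceptors and the ring 1. No available evidence offers an explanation for this result.

Going by these compounds, it remains open whether a terminal amine or a longer chain at this position would shift the number beyond the scatter. On these data alone, compound 2 carries a carboxylic acid but differs from compound 1 in more than one place, so the effect of that group alone also remains open.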